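The source may hold more compounds than are shown below. What is called first, only, known or untested is meant among the compounds shown, and "the series" means these compounds.

In a physicochemical assay for solubility, in phosphate buffer, measured as kinetic solubility, at pH 7.4 (on this read-out lower numbers stand for lower solubility and higher numbers for higher solubility), compound 1 `Cc1oc(-c2c(Cl)cccc2Cl)nc1CN1CCC(C(=O)NCCCN2C[C@H](C)C[C@H](C)C2)CC1` reports > 77 ug/mL as a limit of the assay and not a number. Compound 2 `Cc1oc(-c2c(F)cccc2F)nc1CN1CCC(C(=O)NCCCN2C[C@H](C)C[C@H](C)C2)CC1` reports > 72 ug/mL as a limit too. Among the measured compounds shown here, compound 3 `Cc1oc(-c2c(Cl)cccc2C(F)(F)F)nc1CN1CCC(C(=O)NCCCN2C[C@H](C)C[C@H](C)C2)CC1` gives 65.1 ug/mL as the only actual number of the three values so far, so it is the sole numerical anchor.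

The next step leads to compound 4 `CCc1ccccc1-c1nc(CN2CCC(C(=O)NCCCN3C[C@H](C)C[C@H](C)C3)CC2)c(C)o1` with 2-ethylphenyl in place of 2-chloro-6-(trifluoromethyl)phenyl on an aromatic carbon as the counted difference: 2-ethylphenyl in place of 2-chloro-6-(trifluoromethyl)phenyl on an aromatic carbon of a five-membered aromatic ring with 1 nitrogen and 1 oxygen.

The measured steps that bear on this change all alter the group at the same place. They are a step that the two limits leave unreadable from compound 1 to compound 2 and an at least 1.1-fold lower number from compound 1 to compound 3 (0.07 log units; that floor lies within the scatter) and an at least 1.1-fold lower number from compound 2 to compound 3 (0.04 log units; that floor lies within the scatter) in this series. Neither readable floor goes beyond the scatter, and the remaining step has no readable size. These are floors and not sizes, so the evidence is thin, but no step beyond the scatter is expected in this assay for the new group. Compound 3 at 65.1 ug/mL therefore serves as the starting point for the expectation. The expected result is a 1.0-fold lower number from compound 3 to compound 4 (0.01 log units; within the scatter) with no change beyond the scatter. For compound 4 the estimate is 64 ug/mL with an expected range from 35 ug/mL to 74 ug/mL as its span.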

Compound 4, solubility: 55.9 ug/mL
For compound 4 the middle estimate is 1.1-fold (0.06 log units) above the measured one; measured number inside the range.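

Among the compounds shown here, with 2-ethylphenyl, the group on the aromatic carbon of the five-membered aromatic ring with 1 nitrogen and 1 oxygen carries only carbon for the first time, whereas compounds 1, 2 and 3 all carry fluorine, chlorine or both there; in this assay the result is a 1.2-fold lower number from compound 3 to compound 4 (0.07 log units; within the scatter), so this exchange of 11 heavy atoms for 8 gives no step beyond the scatter. Against the difluoro group, the step is an at least 1.2-fold lower number from compound 2 to compound 4 (0.10 log units; that floor lies within the scatter), and this remains a floor, with compound 2 standing at a limit of the assay and not a number: the limit of > 72 ug/mL in this assay, at which 1 of the 4 values shown sits. Against the dichloro group, the step is an at least 1.3-fold lower number from compound 1 to compound 4 (0.13 log units; that floor lies within the scatter), and this also remains a floor, with compound 1 standing at a limit of the assay and not a number: the limit of > 77 ug/mL in this assay, at which 1 of the 4 values shown sits.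

Going by these compounds, the step between compounds 1 and 2 cannot be read, and the true sizes of the two floors remain open. Also open, on these data alone, is whether a phenyl bearing an amine or a carboxylic acid at this place would give a step beyond the scatter in this assay.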